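Methoxy to ethoxy on the shared core: compound 3

This account rests on a few compounds, and the source may have more. Where it says the series, first, only, none or still open, it means among the compounds named here.

Measured so far:
Compound 2 `CCc1nc2c(C)cc(C)nc2n1Cc1ccc(OC(C(=O)O)c2ccccc2)c(OC)c1` gives 2900 nM.
Compound 1 `CCc1nc2c(C)cc(C)nc2n1Cc1ccc(OC(C(=O)O)c2ccccc2)c(C(C)C)c1` gives 3300 nM.

Going by the values given here, compound 2 has the lowest of the two numbers in an assay on Midbrain with Type-2 angiotensin II receptor (Rattus norvegicus) as the target (a lower number here means a stronger inhibitor, a higher number a weaker inhibitor), but its only neighbour is within the scatter: the step of a 1.1-fold lower number from compound 1 to compound 2 (0.06 log units; within the scatter) is too small to count as a difference, and no order between compound 1 and compound 2 can be read from it.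

Compound 3 `CCOc1cc(Cn2c(CC)nc3c(C)cc(C)nc32)ccc1OC(C(=O)O)c1ccccc1` is compound 2 with methyl in place of hydrogen on a saturated chain carbon bound to an oxygen on an aromatic ring; methoxy becomes ethoxy. A single measured step bears on this change, a 1.1-fold lower number from compound 1 to compound 2 (0.06 log units; within the scatter), in which a replacement of isopropyl by methoxy on the aromatic carbon left the number where it was. Lengthening that methoxy by a methyl is a lesser alteration than that swap, so no step beyond the scatter is expected in this assay, in either direction. Compound 3 is estimated at 2900 nM, range 1200 nM to 7000 nM, a step of no change at the digits printed from compound 2 to compound 3 (within the scatter) from compound 2.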

Compound 3, half-maximal inhibitory concentration: 1200 nM
Compound 3: the middle estimate sits 2.4-fold (0.38 log units) above what was measured; low and high end bracket the measured number.
By their numbers in this assay, from the lowest: compound 3; then compounds 2 and 1 (each within the scatter of the next).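

In this assay, this place on the aromatic carbon responds to one added methyl: methoxy to ethoxy gives a 2.4-fold lower number from compound 2 to compound 3 (0.38 log units; beyond the scatter), whereas the earlier exchange of isopropyl for methoxy gave no readable difference. Ethoxy also separates from isopropyl, with a 2.8-fold lower number from compound 1 to compound 3 (0.44 log units; beyond the scatter), so the substituent here can shift the number even though methoxy and isopropyl could not be told apart. No supporting data accompany these values to explain the shift.

As far as these compounds go, whether a longer chain such as propoxy or butoxy would lower the number further, or reverse the step seen from methoxy to ethoxy, remains open. Also open, from the compounds shown here alone, is how ethoxy would compare in this assay with a hydroxy group or with a simple ethyl group at the same place.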